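A Ring Methyl Tested on a Second Aniline Partner

The compounds below may be only part of what the source reports. "The series", "measured", "known", "first", "only" and "open" are said of these compounds alone.

Compound 1 `Cc1cc(C)cc(Nc2nccc(-c3ccccn3)n2)c1` gives 100 nM in a functional assay for inhibition, with Homo sapiens as the target; a higher number here means a weaker inhibitor, a lower number a stronger inhibitor. Compound 2 `CN(C)c1ccc(Nc2nccc(-c3ccccn3)n2)cc1` gives 3300 nM in this assay, and compound 3 `Cc1cc(-c2ccccn2)nc(Nc2ccc(N(C)C)cc2)n1` gives 31900 nM. The difference between the cores of compound 1 and compound 2 is not broken down here. From compound 2 to compound 3 the change is methyl in place of hydrogen on an aromatic carbon, and it brings a 9.7-fold higher number from compound 2 to compound 3 (0.99 log units; beyond the scatter). Compound 4 `Cc1cc(C)cc(Nc2nc(C)cc(-c3ccccn3)n2)c1` carries the same kind of change relative to compound 1, (methyl in place of hydrogen on an aromatic carbon); around the place, the methyl of compound 4 sits meta to a group of 9 heavy atoms, whereas in compound 3 it sits meta to a large group. Resting on a 9.7-fold higher number from compound 2 to compound 3 (0.99 log units; beyond the scatter), compound 4 is expected to show an 8.0-fold higher number from compound 1 to compound 4 (0.90 log units; beyond the scatter). In this assay compound 4 is estimated at 800 nM, expected to lie between 250 nM and 3000 nM.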

Compound 4, half-maximal inhibitory concentration: > 24000 nM
Compound 4 ended at the assay's limit; the forecaster's own chance of this, stated with the estimate: 3%; middle value at least 30-fold (1.47 log units) from the limit.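

Methyl in place of hydrogen on an aromatic carbon gives an at least 240-fold higher number from compound 1 to compound 4 (2.38 log units; beyond the scatter), so in this assay the size of the change does not carry over from one core to the other: the same change on two cores in this assay, a 9.7-fold higher number (0.99 log units; beyond the scatter) from compound 2 to compound 3 and an at least 240-fold higher number (2.38 log units; beyond the scatter) from compound 1 to compound 4, at least 24-fold (1.39 log units) apart, beyond the scatter of two such steps

The value of compound 4 is a limit of the assay and not a number: the limit of > 24000 nM in this assay, at which 1 of the 4 values shown sits.

Going by these compounds, the number rises on both cores, but the true size of the step to compound 4 stays unknown, and two pairs do not show what sets the cores apart.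

The compounds shown leave open how an ethyl, a methoxy or a chlorine at this place would read on either core. Also open, on these data alone, is how the methyl would behave with an aniline partner carrying an amine or a carboxylic acid.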